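The source may hold more compounds than are shown below. What is called first, only, known or untested is meant among the compounds shown, and "the series" means these compounds.

Measured so far:
- compound 1, `Cc1nc(S(C)(=O)=O)ccc1Oc1ncnc(OC2CCN(C(=O)O[C@@H](C)C(F)(F)F)CC2)c1F`: 9.86 nM
- compound 2, `Cc1nc(S(C)(=O)=O)ccc1Oc1ncnc(OC2CCN(C(=O)SC(C)(C)C)CC2)c1F`: 4.83 nM

In a functional assay on isolated protein for inhibition of Glucose-dependent insulinotropic receptor (Homo sapiens), read by HTRF and cAMP accumulation (on this read-out higher numbers stand for an effect only at larger amounts of compound and lower numbers for an effect already at smaller amounts), compound 2 gives 4.83 nM, the lowest number of the two measured compounds. Its nearest neighbour is compound 1, and the step of a 2.0-fold lower number from compound 1 to compound 2 (0.31 log units; beyond the scatter) shows how far apart they lie. Compound 3, `Cc1nc(S(C)(=O)=O)ccc1Oc1ncnc(OC2CCN(C(=O)SC3(C)CC3)CC2)c1F`, is the next compound to be measured. It differs from compound 2 in one place: 1-methylcyclopropyl in place of tert-butyl on a sulfur. Among the compounds with values here, the single measured step, from compound 1 to compound 2, concerns the group on the carbonyl carbon itself, not what sits on the sulfur beyond it, so no measured step bears directly on this change. Without a comparable step there is no ground to expect a number beyond the scatter in either direction in this assay. Compound 3 is therefore expected to give about 5 nM, within a range of 2 nM to 13 nM. This estimate corresponds to an expected step of a 1.0-fold higher number from compound 2 to compound 3 (0.02 log units; within the scatter).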

Compound 3, half-maximal effective concentration: 13.2 nM
Estimate against measurement, compound 3: 2.6-fold (0.42 log units) below; measured number outside the range, above it.
By their numbers in this assay, from the lowest: compound 2; then compounds 1 and 3 (each within the scatter of the next).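

In this assay, the group on the sulfur matters even when its size in heavy atoms stays the same: a 2.7-fold higher number from compound 2 to compound 3 (0.44 log units; beyond the scatter) comes from replacing tert-butyl with 1-methylcyclopropyl, which has 4 heavy atoms as well but contains a three-membered ring. The second comparison, a 1.3-fold higher number from compound 1 to compound 3 (0.13 log units; within the scatter), concerns the whole group on the carbonyl carbon and shows that the 1-(trifluoromethyl)ethoxy group and the sulfur-linked 1-methylcyclopropyl group cannot be told apart here. No available evidence explains the difference between tert-butyl and 1-methylcyclopropyl on this sulfur.

On these data alone, it remains open whether other groups on the sulfur, such as isopropyl or cyclobutyl, would give numbers nearer compound 2 or compound 3. Also open, as far as these compounds go, is how 1-methylcyclopropyl would behave if attached to the carbonyl carbon through an oxygen instead.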